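Fluoro added to the trifluoromethylphenyl urea arm

The source may report more compounds than this note shows. Statements on the series, on what has been measured and on what is new or still open speak of the compounds shown alone.

Measured so far in a functional assay on MDA-MB-231 cells (Homo sapiens) for inhibition, read by MTT assay and WST assay, with a stated time of 72 h, tested at 10 uM; on this read-out higher numbers stand for more inhibition of growth at the one concentration tested and lower numbers for less inhibition of growth:
compound 1, `O=C(Nc1ccc(Oc2ccc(-c3nccs3)cc2)cc1)Nc1ccc(Cl)c([N+](=O)[O-])c1`, gives 72.8%
compound 2, `O=C(Nc1ccc(Oc2ccc(-c3nccs3)cc2)cc1)Nc1cccc(C(F)(F)F)c1`, gives 64.1%

Compound 2 holds the lowest of the two numbers in this assay; its nearest neighbour is compound 1, the step of a number 8.7 percentage points lower from compound 1 to compound 2 (within the scatter) lying within the scatter. Compound 3, `O=C(Nc1ccc(Oc2ccc(-c3nccs3)cc2)cc1)Nc1ccc(F)c(C(F)(F)F)c1`, differs from compound 2 by fluoro in place of hydrogen on an aromatic carbon. Among the compounds with values here, no measured step adds a fluoro to an aromatic carbon; the only step in hand, a number 8.7 percentage points lower from compound 1 to compound 2 (within the scatter), exchanged the whole aryl group and stayed within the scatter. The expected step from compound 2 is therefore a number 0.9 percentage points higher from compound 2 to compound 3 (within the scatter), none beyond the scatter. Compound 3 is estimated at 65%, range 50% to 80%.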

Compound 3, percent growth inhibition at one concentration: 71.8%
Estimate against measurement, compound 3: 6.8 percentage points below; the measured number falls inside the stated range.
By their numbers in this assay, from the lowest: compounds 2, 3 and 1 (each within the scatter of the next).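

In this assay, fluoro on this aromatic carbon, ortho to a trifluoromethyl group and para to a large group, gives a number 7.7 percentage points higher from compound 2 to compound 3 (within the scatter), so this position tolerates the added atom with no step beyond the scatter. Exchanging the whole aryl group leaves the 4-fluoro-3-(trifluoromethyl)phenyl arm with a number 1 percentage points lower from compound 1 to compound 3 (within the scatter), again inside the scatter. No supporting evidence bears on either step. Going by these compounds, whether an amine or a methoxy group on this same carbon would give a step beyond the scatter remains open. So does the read-out of these compounds at other concentrations.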